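Shortening the Enamide Chain on a Second Core

The source may hold more compounds than are shown below. What is called first, only, known or untested is meant among the compounds shown, and "the series" means these compounds.

Compound 1 `CCC/C=C/C(=O)Nc1cccc(Oc2nc(Nc3ccn(C)n3)nc3c2CSCC3)c1` and compound 2 `CC(C)=CC(=O)Nc1cccc(Oc2nc(Nc3ccn(C)n3)nc3c2CSCC3)c1` share one core and differ only at the carbonyl carbon: 2-methylprop-1-en-1-yl in place of pent-1-en-1-yl on a carbonyl carbon. In a functional assay on A549 cells (Homo sapiens) for antiproliferative activity, read by MTT assay, with a stated time of 72 h (on this read-out higher numbers stand for weaker inhibition and lower numbers for stronger inhibition), compound 1 gives 8190 nM and compound 2 gives 44200 nM, so that a 5.4-fold higher number from compound 1 to compound 2 (0.73 log units; beyond the scatter). Compound 3 `CCC/C=C/C(=O)Nc1cccc(Oc2nc(Nc3cccc(C#N)c3)nc3c2CSCC3)c1` carries the same pent-1-en-1-yl chain as compound 1 on a different core; the two cores differ in one way: 3-cyanophenyl in place of 1-methyl-1H-pyrazol-3-yl on a nitrogen on an aromatic ring. In this assay compound 3 gives 5790 nM, and a 1.4-fold lower number from compound 1 to compound 3 (0.15 log units; within the scatter). Compound 4 `CC(C)=CC(=O)Nc1cccc(Oc2nc(Nc3cccc(C#N)c3)nc3c2CSCC3)c1` has not been measured; it stands to compound 3 as compound 2 stands to compound 1, the same change at the same place: 2-methylprop-1-en-1-yl in place of pent-1-en-1-yl on a carbonyl carbon. Because a 5.4-fold higher number from compound 1 to compound 2 (0.73 log units; beyond the scatter) lies beyond the scatter, a step of similar size is expected here: a 4.8-fold higher number from compound 3 to compound 4 (0.68 log units; beyond the scatter). For compound 4 the estimated value in this assay is 28000 nM, expected between 12000 nM and 70000 nM.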

Compound 4, half-maximal inhibitory concentration: 36900 nM
Estimate against measurement, compound 4: 1.3-fold (0.12 log units) below; the range from low to high includes it.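

In this assay, 2-methylprop-1-en-1-yl in place of pent-1-en-1-yl on the carbonyl carbon gives a 6.4-fold higher number from compound 3 to compound 4 (0.80 log units; beyond the scatter), and this step carries over between the two cores: the same change on two cores in this assay, a 5.4-fold higher number (0.73 log units; beyond the scatter) from compound 1 to compound 2 and a 6.4-fold higher number (0.80 log units; beyond the scatter) from compound 3 to compound 4, 1.2-fold (0.07 log units) apart, within the scatter of two such steps With the chain held constant, 3-cyanophenyl in place of 1-methyl-1H-pyrazol-3-yl gives a 1.2-fold lower number from compound 2 to compound 4 (0.08 log units; within the scatter), which agrees with the earlier step for that change: the same change on two cores in this assay, a 1.4-fold lower number (0.15 log units; within the scatter) from compound 1 to compound 3 and a 1.2-fold lower number (0.08 log units; within the scatter) from compound 2 to compound 4, 1.2-fold (0.07 log units) apart, within the scatter of two such steps This shows that the two changes behave alike across these four compounds in this one assay, but it does not show that they would do so on any further core, nor does it explain why the chain change matters.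

The compounds shown leave open how a longer chain or a saturated pentyl chain would behave on the carbonyl carbon. They also leave open whether a chain ending in an amine would follow the same pattern on both cores.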